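Aryl swaps on the triazole nitrogen of the shared core

A few compounds are considered here, and "the series" means these few. Any claim that something is new, unique, unknown or untested is made for them only; others in the source may bear on it.

compound 1 `N#CC1=C(N)Oc2c(c3nc4ccccc4nc3c3ccccc23)C12C(=O)N(Cc1cnnn1-c1cccc(Cl)c1)c1ccccc12` — 32600 nM
compound 2 `COc1ccccc1-n1nncc1CN1C(=O)C2(C(C#N)=C(N)Oc3c2c2nc4ccccc4nc2c2ccccc32)c2ccccc21` — > 50000 nM
compound 3 `N#CC1=C(N)Oc2c(c3nc4ccccc4nc3c3ccccc23)C12C(=O)N(Cc1cnnn1-c1ccc(N)cc1)c1ccccc12` — > 50000 nM

In a functional assay on A549 cells (Homo sapiens) for antiproliferative activity, read by MTT assay, with a stated time of 48 h (a higher number here means a weaker inhibitor, a lower number a stronger inhibitor), compound 1 gives 32600 nM. For compound 2 the value > 50000 nM is a limit of this assay, not a number. For compound 3 the value > 50000 nM is likewise a limit. Compound 3 therefore stands at the limit of > 50000 nM in this assay, at which 2 of the 3 values shown sit, and its relation to compound 2 cannot be read: a step that the two limits leave unreadable from compound 2 to compound 3.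

Compound 4 `N#CC1=C(N)Oc2c(c3nc4ccccc4nc3c3ccccc23)C12C(=O)N(Cc1cnnn1-c1ccc(F)c(Cl)c1)c1ccccc12` differs from compound 3 in one place: 3-chloro-4-fluorophenyl in place of 4-aminophenyl on an aromatic nitrogen. Of the measured steps, an at least 1.5-fold higher number from compound 1 to compound 3 (0.18 log units; that floor lies within the scatter) bears on it most closely, as it runs from a 3-chlorophenyl to the same 4-aminophenyl; an at least 1.5-fold higher number from compound 1 to compound 2 (0.18 log units; that floor lies within the scatter) runs the same way. Read in reverse, a halogen-bearing phenyl in place of 4-aminophenyl is expected to give a somewhat lower number, though the floors of both steps lie within the scatter. The expected step is an at least 1.6-fold lower number from compound 3 to compound 4 (0.22 log units; that floor lies within the scatter). Compound 4 is estimated at 30000 nM, between 10000 nM and 60000 nM, with a real chance that only a limit is reported.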

Compound 4, half-maximal inhibitory concentration: > 50000 nM
Compound 4: only a limit was reported; the forecaster's own chance of this, stated with the estimate: 35%; middle value at least 1.6-fold (0.22 log units) away from the limit.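

In this assay compound 4 gives > 50000 nM, a limit of the assay and not a number, even with a halogen-bearing 3-chloro-4-fluorophenyl on the aromatic nitrogen. Fluoro in place of hydrogen on an aromatic carbon gives an at least 1.5-fold higher number from compound 1 to compound 4 (0.18 log units; that floor lies within the scatter), so the floor of this step lies within the scatter and a real loss is not shown, yet a chlorine on the phenyl is no longer enough to go with a measured value. The steps to compound 4 from the other two limit compounds cannot be read, and the set now sits largely at one limit: the limit of > 50000 nM in this assay, at which 3 of the 4 values shown sit.

From the compounds shown here alone, whether any group on this nitrogen gives a value well clear of that limit stays open. Also open, going by these compounds, is how a bromine on the phenyl, or a benzyl group or a longer alkyl chain in place of the phenyl, would read here.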